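Swapping the Aryl Group on the Ring Nitrogen of Compound 1

The source may hold more compounds than are shown below. What is called first, only, known or untested is meant among the compounds shown, and "the series" means these compounds.

Measured compounds:
compound 1 `Nc1scc(CN2CCN(c3ccc(F)cc3Cl)CC2)c1C(=O)c1ccc(Cl)cc1`, -70%
compound 2 `Nc1scc(CN2CCN(c3cccnc3)CC2)c1C(=O)c1ccc(Cl)cc1`, -23%
compound 3 `Nc1scc(CN2CCN(c3cccc4ccccc34)CC2)c1C(=O)c1ccc(Cl)cc1`, -21%

In a functional assay on CHO cells with adenosine receptor A1 (Homo sapiens) as the target, read by cAMP accumulation and immunoassay, with a stated time of 6 min, tested at 10 uM (a lower number here means a stronger effect, a higher number a weaker effect of the compound at the concentration tested), compound 1 stands lowest of the three numbers, and both steps away from it are beyond the scatter: a number 47 percentage points higher from compound 1 to compound 2 (beyond the scatter) and a number 49 percentage points higher from compound 1 to compound 3 (beyond the scatter). The two other compounds lie together, since a number 2 percentage points higher from compound 2 to compound 3 (within the scatter).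

Compound 4 `Nc1scc(CN2CCN(c3cccc(F)c3F)CC2)c1C(=O)c1ccc(Cl)cc1` has not yet been measured. It differs from compound 1 by 2,3-difluorophenyl in place of 2-chloro-4-fluorophenyl on an amine nitrogen in a ring. Both measured steps from compound 1 exchanged the 2-chloro-4-fluorophenyl group and each produced a large weakening, so a weakening is expected here too, though compound 4 keeps a phenyl ring carrying two halogens and the step is expected to be smaller: a number 20 percentage points higher from compound 1 to compound 4 (beyond the scatter). Compound 4 is estimated at -50%, within -78% to -20%.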

Compound 4, a percentage reported as activity, at one concentration (the size of the read-out at that concentration, not a potency): -79%
Beside the measured number, compound 4's estimate is 29 percentage points above it; measured number below the stated range.
By their numbers in this assay, from the lowest: compounds 4 and 1 (each within the scatter of the next); then compounds 2 and 3 (each within the scatter of the next).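

Placing 2,3-difluorophenyl on the amine nitrogen in a ring gives a number 9 percentage points lower from compound 1 to compound 4 (within the scatter) in this assay and so shows that the effect of compound 1 does not depend on its chlorine or on the 2-chloro-4-fluorophenyl pattern. The new group also stands well apart from the other two aryl groups, with a number 58 percentage points lower from compound 3 to compound 4 (beyond the scatter) and with a number 56 percentage points lower from compound 2 to compound 4 (beyond the scatter) as well. Nothing available here accounts for these differences.

The compounds shown leave open whether a single fluorine on the phenyl ring, or an unsubstituted phenyl, would keep this effect. They also leave open how a methoxy or trifluoromethyl group on that ring would compare.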